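The source may hold more compounds than are shown below. What is called first, only, known or untested is meant among the compounds shown, and "the series" means these compounds.

Compound 1 `O=C(CNC(=O)c1nn(-c2ccccc2)c(=O)c2ccccc12)Nc1nccs1` and compound 2 `O=C(CSc1nc2c(c(=O)n1-c1ccccc1)SCC2)Nc1ccc(N2CCCCC2)cc1` are the two members of the series with a result in an assay on L cells for inhibition of Protein-serine O-palmitoleoyltransferase porcupine (Mus musculus), read by reporter gene assay, with a stated time of 24 h; a lower number here means that less compound is needed, a higher number that more compound is needed for the effect. For compound 1 this assay returns only a limit, > 25000 nM, which is the boundary of the assay and not a number; see (the limit of > 25000 nM in this assay, at which 1 of the 2 values shown sits). Going by the values given here, compound 2 gives 30 nM in this assay, and that is the only actual number in the set, so compound 2 is the sole anchor for any estimate. Compound 3 `CCOc1ccc(NC(=O)CSc2nc3c(c(=O)n2-c2ccccc2)SCC3)cc1` is not yet measured. It differs from compound 2 in one place: ethoxy in place of piperidin-1-yl on an aromatic carbon. Among the compounds with values here, no measured step of a single change exists, so the size of the effect of this exchange has no precedent here. The step from compound 2 to compound 3 is expected to be a loss of moderate size, a 5.0-fold higher number from compound 2 to compound 3 (0.70 log units; beyond the scatter), beyond the usual scatter. Compound 3 is therefore estimated at 150 nM in this assay, with a range from 40 nM to 600 nM.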

Compound 3, half-maximal effective concentration: 1000 nM
Beside the measured number, compound 3's estimate is 6.7-fold (0.82 log units) below it; measured number outside the range, above it.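

In this assay, the series now has its first measured single change, and it is a large one: a 33-fold higher number from compound 2 to compound 3 (1.52 log units; beyond the scatter). The group on this aromatic carbon, para to a large group, therefore strongly affects the read-out, even though piperidin-1-yl and ethoxy match in their counts of hydrogen-bond donors and acceptors, so those counts alone do not separate compound 2 from compound 3. Nothing measured here gives a cause for the size of this step.

Going by these compounds, it remains open whether the lower number of compound 2 goes with the ring, its nitrogen or its size. Morpholin-4-yl, pyrrolidin-1-yl or diethylamino on the same carbon would help to separate these, while a longer alkoxy chain would extend the comparison from ethoxy.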